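Replacing oxolan-3-yl in compound 3

The source may hold more compounds than are shown below. What is called first, only, known or untested is meant among the compounds shown, and "the series" means these compounds.

In a functional assay on HeLa cells (Homo sapiens) for cytotoxicity, read by MTT assay (on this read-out lower numbers stand for stronger inhibition and higher numbers for weaker inhibition), compound 3 `CC(C)=CC[C@@H](OC(=O)C1CCOC1)C1=CC(=O)c2c(O)ccc(O)c2C1=O` gives 73500 nM, within the scatter of compound 1 `COCCO[C@H](CC=C(C)C)C1=CC(=O)c2c(O)ccc(O)c2C1=O` at 62400 nM. For compound 2 `CCCCCCC(C)(O)CC(=O)O[C@H](CC=C(C)C)C1=CC(=O)c2c(O)ccc(O)c2C1=O` the read-out is a limit and not a number, > 100000 nM. Compound 4 `CCC(C)(O)CC(=O)O[C@H](CC=C(C)C)C1=CC(=O)c2c(O)ccc(O)c2C1=O` carries 2-hydroxy-2-methylbutyl in place of oxolan-3-yl on a carbonyl carbon. Among the measured compounds shown here, two measured steps bear on this change: a 1.2-fold higher number from compound 1 to compound 3 (0.07 log units; within the scatter), and an at least 1.3-fold lower number from compound 2 to compound 3 (0.13 log units; that floor lies within the scatter). Neither gives grounds for a step beyond the scatter, so none is expected in this assay. The estimate therefore means a 1.1-fold higher number from compound 3 to compound 4 (0.04 log units; within the scatter). Compound 4 is expected at about 80000 nM, with an estimated range of 40000 nM to 130000 nM.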

Compound 4, half-maximal inhibitory concentration: 25200 nM
The estimate for compound 4 lay 3.2-fold (0.50 log units) above the measured number, and the stated range ends above it.
By their numbers in this assay, from the lowest: compound 4; then compounds 1 and 3 (each within the scatter of the next). At a limit, above all of these: compound 2.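

In this assay, this change on the carbonyl carbon is the first shown to move the number beyond the scatter: a 2.9-fold lower number from compound 3 to compound 4 (0.46 log units; beyond the scatter). Against compound 1 the result is a 2.5-fold lower number from compound 1 to compound 4 (0.39 log units; beyond the scatter), and hydrogen in place of butyl on a saturated chain carbon gives an at least 3.9-fold lower number from compound 2 to compound 4 (0.59 log units; beyond the scatter). That last step is only a floor, since compound 2 is read as a limit and not a number: the limit of > 100000 nM in this assay, at which 1 of the 4 values shown sits.

The compounds shown do not separate the hydroxy group of 2-hydroxy-2-methylbutyl from its open chain. As far as these compounds go, how an amine or a carboxylic acid on this carbonyl carbon would read remains open.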